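Cyclic amide to benzyl carbamate: what compound 3 may show

A few compounds are considered here, and "the series" means these few. Any claim that something is new, unique, unknown or untested is made for them only; others in the source may bear on it.

Measured compounds:
compound 1 `Cc1cc(NC(=O)C2CCCC2)nn1Cc1cc(Cl)ccc1OCc1ccccc1`, 15.9 nM
compound 2 `Cc1cc(NC(=O)C2CCCO2)nn1Cc1cc(Cl)ccc1OCc1ccccc1`, 39.8 nM

In an assay on CHO-K1 cells for displacement of a labelled ligand from prostaglandin E2 receptor EP1 subtype (Homo sapiens) (a lower number here means a stronger inhibitor, a higher number a weaker inhibitor), compound 1 gives 15.9 nM and compound 2 gives 39.8 nM. Within the data shown here, the single measured step, a 2.5-fold higher number from compound 1 to compound 2 (0.40 log units; beyond the scatter), shows that trading the all-carbon ring for its oxygen-containing counterpart cost some potency. Compound 2 therefore stands with the higher of the two numbers, the weaker of the pair.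

Compound 3 `Cc1cc(NC(=O)OCc2ccccc2)nn1Cc1cc(Cl)ccc1OCc1ccccc1` differs from compound 2 by benzyloxy in place of oxolan-2-yl on a carbonyl carbon. Among the measured compounds shown here, no measured step covers this kind of change; the only one available, the shift from compound 1 to compound 2, concerns a different replacement at the same carbonyl carbon and was modest. Compound 3 is thus expected to land near compound 2, with a slight further weakening allowed for in the estimate: a 1.5-fold higher number from compound 2 to compound 3 (0.18 log units; within the scatter). Compound 3 is estimated at 60 nM, within the range 15 nM to 250 nM.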

Compound 3, half-maximal inhibitory concentration: 79.4 nM
For compound 3 the middle estimate is 1.3-fold (0.12 log units) below the measured one; the range from low to high includes it.
By their numbers in this assay, from the lowest: compound 1; then compounds 2 and 3 (each within the scatter of the next).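

In this assay, the position on the carbonyl carbon tolerates benzyloxy, with its six-membered aromatic ring, about as well as oxolan-2-yl: the change gives a 2.0-fold higher number from compound 2 to compound 3 (0.30 log units; within the scatter), so no difference between the two groups can be read. Measured against cyclopentyl, however, benzyloxy gives a 5.0-fold higher number from compound 1 to compound 3 (0.70 log units; beyond the scatter), which leaves compound 1 the strongest inhibitor of the three, with both of its steps beyond the scatter. Nothing shown here explains these numbers.

The three compounds leave open whether benzylamino on the same carbonyl carbon, which would turn the linkage into a urea, would read differently from benzyloxy. They also leave open how a longer chain such as 2-phenylethoxy, or a simple amine such as dimethylamino, would compare with cyclopentyl.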